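A Second Chloro Joins the Phenol Ring

The source may report more compounds than this note shows. Statements on the series, on what has been measured and on what is new or still open speak of the compounds shown alone.

Two compounds share one core and differ only in a single group on the hydroxy-bearing ring. Compound 1 `C/C(=N\NC(=O)c1cc(-c2ccccc2)nn1Cc1ccc(C(C)(C)C)cc1)c1cc(C)ccc1O` carries a methyl there, and in a functional assay on A549 cells (Homo sapiens) for inhibition, read by MTT assay, with a stated time of 48 h (a higher number here means a weaker inhibitor, a lower number a stronger inhibitor), compound 1 gives 6100 nM. Compound 2 `C/C(=N\NC(=O)c1cc(-c2ccccc2)nn1Cc1ccc(C(C)(C)C)cc1)c1cc(Cl)ccc1O` carries a chloro instead, and in this assay compound 2 gives 2770 nM. Going by the values given here, that swap, a 2.2-fold lower number from compound 1 to compound 2 (0.34 log units; beyond the scatter), is the only step measured so far, and it leaves compound 2 with the lowest of the two numbers, a position that holds beyond the scatter.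

Compound 3 `C/C(=N\NC(=O)c1cc(-c2ccccc2)nn1Cc1ccc(C(C)(C)C)cc1)c1cc(Cl)cc(Cl)c1O` takes the next step: chloro in place of hydrogen on an aromatic carbon, so the ring now carries two chloro groups flanking the hydroxy. Among the compounds with values here, no measured pair shows this exact change. Within the data shown here, the one measured step, the methyl-to-chloro swap from compound 1 to compound 2, was modest and favourable, so a chloro on this ring has so far not hurt. A second chloro at a new place is a different change, and only a small shift, at most modest, is expected. Compound 3 is therefore estimated at 1800 nM, within 700 nM to 4500 nM, a step of a 1.5-fold lower number from compound 2 to compound 3 (0.19 log units; within the scatter).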

Compound 3, half-maximal inhibitory concentration: 3170 nM
Compound 3: the middle estimate sits 1.8-fold (0.25 log units) below what was measured; low and high end bracket the measured number.
By their numbers in this assay, from the lowest: compounds 2, 3 and 1 (each within the scatter of the next, the first and the last beyond it).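

In this assay, a chloro placed ortho to a hydroxy group, on a ring that already holds one chloro, gives a 1.1-fold higher number from compound 2 to compound 3 (0.06 log units; within the scatter), so this position accepts a second chloro with no readable change in the number. Across both ring changes together, the record shows a 1.9-fold lower number from compound 1 to compound 3 (0.28 log units; within the scatter), whereas the single swap of methyl for chloro went beyond the scatter, so the second chloro adds nothing readable to what the first one gave. The data at hand offer no measurement that could explain why the number holds steady at this position.

Still open, going by these compounds, is whether this position responds to anything other than chloro, since a methoxy group, a fluoro or an amine here could move the number in either direction, and hydrogen and chloro alone cannot show how wide that tolerance runs. Also open, on these data alone, is what the hydroxy group itself contributes, as it stands in all three compounds and so its part in these numbers cannot be read from them.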